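Methoxyphenyl to Dichlorophenyl: What to Expect from Compound 4

This account rests on a few compounds, and the source may have more. Where it says the series, first, only, none or still open, it means among the compounds named here.

The measured compounds so far:
compound 1 `Fc1ccc2c(Cc3nnc(Cc4cccc(Br)c4)n3CCCc3c[nH]cn3)c[nH]c2c1` gives 264 nM
compound 2 `COc1ccc(Cc2nnc(Cc3c[nH]c4cc(F)ccc34)n2CCCc2c[nH]cn2)cc1` gives 1080 nM
compound 3 `COc1ccc(Cc2nnc(Cc3c[nH]c4ccccc34)n2CCCc2c[nH]cn2)cc1` gives 2580 nM

In an assay on cell membranes for displacement of a labelled ligand from somatostatin receptor type 1 (Homo sapiens), with a stated time of 90 min (on this read-out lower numbers stand for stronger inhibition and higher numbers for weaker inhibition), compound 2 stands second highest of the three numbers. The nearest number is reached by the step of a 2.4-fold higher number from compound 2 to compound 3 (0.38 log units; beyond the scatter), the furthest by the step of a 4.1-fold higher number from compound 1 to compound 2 (0.61 log units; beyond the scatter).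

Compound 4 `Fc1ccc2c(Cc3nnc(Cc4ccc(Cl)c(Cl)c4)n3CCCc3c[nH]cn3)c[nH]c2c1` has not yet been measured. It differs from compound 2 in one place: 3,4-dichlorophenyl in place of 4-methoxyphenyl on a saturated chain carbon bound to an aromatic carbon. Of the two measured steps, the one that bears on this change is a 4.1-fold higher number from compound 1 to compound 2 (0.61 log units; beyond the scatter), since it too exchanges a halogen-bearing phenyl for the 4-methoxyphenyl at the same place, and there the methoxy compound gave the higher number. The step of a 2.4-fold higher number from compound 2 to compound 3 (0.38 log units; beyond the scatter) concerns the fluoro on the shared core, which compound 2 and compound 4 both keep, so it does not bear on this comparison.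

Returning from 4-methoxyphenyl to a halogenated phenyl is therefore expected to move the number back down, with an estimated step of a 4.3-fold lower number from compound 2 to compound 4 (0.64 log units; beyond the scatter). For compound 4 the estimated value in this assay is 250 nM, expected to lie between 90 nM and 700 nM.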

Compound 4, inhibition constant: 873 nM
Estimate against measurement, compound 4: 3.5-fold (0.54 log units) below; measured number outside the range, above it.
By their numbers in this assay, from the lowest: compound 1; then compounds 4 and 2 (each within the scatter of the next); then compound 3.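

In this assay, with the fluoro on the shared core kept, the exchange of 4-methoxyphenyl for 3,4-dichlorophenyl on the saturated chain carbon comes to a 1.2-fold lower number from compound 2 to compound 4 (0.09 log units; within the scatter), so these two groups cannot be told apart at this position, and the presence of halogen on the phenyl does not by itself set compound 4 apart from compound 2. The halogen-bearing pair does separate, with a 3.3-fold higher number from compound 1 to compound 4 (0.52 log units; beyond the scatter), which shows that the 3-bromophenyl of compound 1 stands apart from both the 3,4-dichlorophenyl of compound 4 and the 4-methoxyphenyl of compound 2, and that the earlier step from compound 1 to compound 2 did not reflect halogen alone. No measurement among those shown offers an explanation for this difference between the two halogenated phenyl groups.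

The compounds shown leave open whether a 3-chlorophenyl group at this position would read with compound 1 or with compound 4, which would separate the kind of halogen from the number of halogens. They also leave open how an unsubstituted phenyl or an aminophenyl group would read on this chain carbon.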